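The source may hold more compounds than are shown below. What is called first, only, known or untested is meant among the compounds shown, and "the series" means these compounds.

The series is read in a functional assay on MDA-MB-435 cells (Homo sapiens) for cytotoxicity, read by MTT assay, with a stated time of 72 h; on this read-out lower numbers stand for stronger inhibition and higher numbers for weaker inhibition. Going by the values given here, compound 1 `COc1ccc(CNC(=O)c2nc(Br)c3cccnc3c2N[C@H]2CC[C@H](N)CC2)cc1` is the only member for which a numerical result exists: in this assay compound 1 gives 5000 nM. Compound 2 `C[C@@H](CO)Nc1nc(C(=O)NCc2ccc(F)cc2)c(O)c2ncccc12` returns no number at all; in this assay compound 2 gives > 20000 nM, which is a limit of the assay. Compound 1 therefore stands as the sole measured point, and the other entry sits at the limit of > 20000 nM in this assay, at which 1 of the 2 values shown sits. Among the compounds with values here, no pair of measured compounds differing in a single place is available, so no measured step can be stated.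

Compound 3 `N[C@H]1CC[C@H](Nc2c(C(=O)NC3CCCCC3)nc(Br)c3cccnc23)CC1` has not yet been tested. It differs from compound 1 at one position, (cyclohexyl in place of 4-methoxybenzyl on an amide-type nitrogen), so the amide nitrogen carries a saturated ring instead of the methoxy-substituted benzyl. With compound 1 already a weak inhibitor and nothing in the data to anchor the effect of this change, the step from compound 1 to compound 3 is expected to be small, no larger than the scatter, with a slight lean toward weaker inhibition, as a 1.6-fold higher number from compound 1 to compound 3 (0.20 log units; within the scatter) expresses. In this assay compound 3 is estimated at 8000 nM, within a range from 2500 nM to 20000 nM.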

Compound 3, half-maximal inhibitory concentration: > 10000 nM
Compound 3: a limit, no number (the forecaster's own chance of this, stated with the estimate: 30%); middle value at least 1.2-fold (0.09 log units) away from the limit.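

In this assay, cyclohexyl in place of 4-methoxybenzyl on an amide-type nitrogen gives the series its first comparison at a single position, and the change reads as an at least 2.0-fold higher number from compound 1 to compound 3 (0.30 log units; that floor lies within the scatter). The saturated ring therefore shows no sign of stronger inhibition than the 4-methoxybenzyl group at this position, although the floor of the step does not by itself take compound 3 beyond the usual scatter from compound 1. Compound 3 carries a limit and not a number, so the true size of the step cannot be read and the loss could be small or much larger: the limit of > 10000 nM in this assay, at which 1 of the 3 values shown sits.

The compounds shown leave open whether the reading at this position follows the aromatic ring of the 4-methoxybenzyl group or its methoxy substituent, a question that an unsubstituted benzyl group on the same amide-type nitrogen would address. It also remains open how a longer chain such as 2-phenylethyl would read here on the core of compound 1, since the single step shown covers only one replacement at this position.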